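The compounds below may be only part of what the source reports. "The series", "measured", "known", "first", "only" and "open" are said of these compounds alone.

Compound 1 `COc1ccc(-c2cnc(NC(=O)c3ccn[nH]3)n2C)cc1` sits at a limit of the assay in a toxicity assay on THP-1 cells (Homo sapiens) for inhibition; on this read-out higher numbers stand for lower toxicity in this test and lower numbers for higher toxicity in this test: its reading of > 100000 nM is a limit, not a number. Compound 1 therefore has no measured value of its own, and one of the two other values shown is a limit as well. Compound 3 `COc1ccc(-c2cnc(NC(=O)c3cc(-c4ccccn4)n[nH]3)n2C)cc1`, carrying pyridin-2-yl in place of hydrogen on an aromatic carbon, reads >= 50000 nM in this assay, also a limit. The step that the two limits leave unreadable from compound 1 to compound 3 cannot be read, since the two limits the limit of > 100000 nM in this assay, at which 1 of the 3 values shown sits, and the limit of >= 50000 nM in this assay, at which 1 of the 3 values shown sits, hide its size. Among the measured compounds shown here, compound 2 `Cn1c(-c2ccc(Cl)cc2)cnc1NC(=O)c1ccc(F)cc1` is the only compound with a number, giving 37000 nM in this assay. Compound 4 `COc1ccc(-c2cnc(NC(=O)c3ccccc3C#N)n2C)cc1` differs from compound 1 by 2-cyanophenyl in place of 1H-pyrazol-5-yl on a carbonyl carbon. For the measured compounds named here, no measured step bears readably on this change, so no direction can be set beyond the scatter. Compound 4 is expected to give about 60000 nM, within 20000 nM and 150000 nM. The step of an at least 1.6-fold lower number from compound 1 to compound 4 (0.22 log units; that floor lies within the scatter) that this estimate means is expected to stay small, and the reading may again be a limit.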

Compound 4, half-maximal cytotoxic concentration: > 100000 nM
Compound 4 was reported as a limit (the forecaster's own chance of this, stated with the estimate: 55%); middle value at least 1.6-fold (0.22 log units) from the limit.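

In this assay compound 4 reads > 100000 nM, which is a limit and not a number. Compound 1 sits at this same limit, so no step can be read between compound 1 and compound 4: the limit of > 100000 nM in this assay, at which 2 of the 4 values shown sit.

Going by these compounds, whether 2-cyanophenyl or 1H-pyrazol-5-yl on the carbonyl carbon gives the lower toxicity in this assay stays open.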